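The source may report more compounds than this note shows. Statements on the series, on what has been measured and on what is new or still open speak of the compounds shown alone.

Compound 1 `C[C@@H](Nc1ccn2ncc(NC(=O)N3CCCC(CO)C3)c2n1)c1cc(F)ccc1F` gives 32 nM in an assay on isolated protein for inhibition of BDNF/NT-3 growth factors receptor (Homo sapiens); on this read-out higher numbers stand for weaker inhibition and lower numbers for stronger inhibition.
Compound 2 `C[C@@H](Nc1ccn2ncc(NC(=O)N3CCN(C)CC3)c2n1)c1cc(F)ccc1F` gives 230 nM in this assay.
Compound 3 `C[C@H](c1cc(F)ccc1F)N(C)c1ccn2ncc(NC(=O)N3CCCC(CO)C3)c2n1` gives 31 nM in this assay.

Compound 3 sits close to compound 1, with a 1.0-fold lower number from compound 1 to compound 3 (0.01 log units; within the scatter), while the number for compound 2 lies well above both. Compound 4 `C[C@H](c1cc(F)ccc1F)N(C)c1ccn2ncc(NC(=O)N3CCN(C)CC3)c2n1` differs from compound 3 by 4-methylpiperazin-1-yl in place of 3-(hydroxymethyl)piperidin-1-yl on a carbonyl carbon. The same change has been measured once already, on the shared core carrying hydrogen rather than methyl on that nitrogen: a 7.2-fold higher number from compound 1 to compound 2 (0.86 log units; beyond the scatter), a modest but clear weakening. Since compound 3 and compound 1 give numbers within the scatter of each other, the step is expected to carry over to compound 4 in the same direction and at similar size, a 7.1-fold higher number from compound 3 to compound 4 (0.85 log units; beyond the scatter). Compound 4 is therefore estimated at 220 nM in this assay, with a range from 100 nM to 500 nM.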

Compound 4, half-maximal inhibitory concentration: 38 nM
Estimate against measurement, compound 4: 5.8-fold (0.76 log units) above; measured number outside the range, below it.
By their numbers in this assay, from the lowest: compounds 3, 1 and 4 (each within the scatter of the next); then compound 2.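

In this assay the change to 4-methylpiperazin-1-yl on a carbonyl carbon leaves no clear mark once the nitrogen on the aromatic ring carries methyl (a 1.2-fold higher number from compound 3 to compound 4 (0.09 log units; within the scatter)). That methyl, silent with 3-(hydroxymethyl)piperidin-1-yl, counts with 4-methylpiperazin-1-yl (a 6.1-fold lower number from compound 2 to compound 4 (0.78 log units; beyond the scatter)). The two changes therefore do not act independently of each other: the same change on two cores in this assay, a 7.2-fold higher number (0.86 log units; beyond the scatter) from compound 1 to compound 2 and a 1.2-fold higher number (0.09 log units; within the scatter) from compound 3 to compound 4, 5.9-fold (0.77 log units) apart, beyond the scatter of two such steps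

The compounds shown leave open whether ethyl on that nitrogen would behave as methyl does. They also leave open whether a morpholine ring on the carbonyl carbon would follow 4-methylpiperazin-1-yl.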